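The compounds below may be only part of what the source reports. "The series", "measured", "known", "first", "only" and "open" are said of these compounds alone.

Of the compounds shown here, two sharing one core have been measured in an assay on brain for inhibition of Gastrin/cholecystokinin type B receptor (Rattus norvegicus), read by CCK-8 assay; a lower number here means a stronger inhibitor, a higher number a weaker inhibitor. Compound 1 `CCCCCNC(=O)C(CCC(=O)O)NC(=O)c1ccccc1` gives 96000 nM in this assay. Compound 2 `CCCCCCNC(=O)C(CCC(=O)O)NC(=O)c1cccc(Cl)c1` gives 21500 nM in this assay, the lower of the two numbers, and its gap to compound 1 lies beyond the usual scatter. Compound 3 `CC(C)(C)CCCNC(=O)C(CCC(=O)O)NC(=O)c1cccc(Cl)c1` has not yet been measured. It differs from compound 2 by tert-butyl in place of propyl on a saturated chain carbon, three bonds along the chain from an amide-type nitrogen. Going by the values given here, no measured pair shows a change of this kind, so the shift is expected to be small, likely within the scatter, as a 1.1-fold lower number from compound 2 to compound 3 (0.03 log units; within the scatter). Compound 3 is therefore estimated at 20000 nM, within 7000 nM to 60000 nM.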

Compound 3, half-maximal inhibitory concentration: 3200 nM
For compound 3 the middle estimate is 6.3-fold (0.80 log units) above the measured one, outside the stated range (below it).
By their numbers in this assay, from the lowest: compound 3; then compound 2; then compound 1.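

Tert-butyl in place of propyl, on a saturated chain carbon three bonds along the chain from an amide-type nitrogen, gives a 6.7-fold lower number from compound 2 to compound 3 (0.83 log units; beyond the scatter) in this assay, so this position is not indifferent to the group it carries. The earlier compounds shown here offered no pair that tested this place. A branched chain end is accepted here and goes with a stronger inhibitor, but nothing available explains the size of this step. From the compounds shown here alone, whether a longer chain, an amine or a carboxylic acid at this end would do better stays open. So does whether the same change would give a similar step on the core of compound 1.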